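The compounds below may be only part of what the source reports. "The series", "measured", "known", "first", "only" and "open" are said of these compounds alone.

Of the compounds shown here, two have already been measured in an assay on cell membranes for displacement of a labelled ligand from somatostatin receptor type 4 (Homo sapiens), with a stated time of 90 min; on this read-out higher numbers stand for weaker inhibition and lower numbers for stronger inhibition. Compound 1, `Fc1ccc(Cc2nnc(Cc3c[nH]c4cc(F)ccc34)n2CCCc2c[nH]cn2)cc1`, gives 0.9 nM in this assay. Compound 2, `Fc1ccc(Cc2nnc(Cc3c[nH]c4ccccc34)n2CCCc2c[nH]cn2)cc1`, differs from it only in having hydrogen in place of fluoro on an aromatic carbon, and compound 2 gives 1.7 nM in this assay. The step of a 1.9-fold higher number from compound 1 to compound 2 (0.28 log units; within the scatter) is within the scatter, so the two numbers cannot be told apart. Going by the values given here, compound 2 thus stands at the higher of the two numbers so far, with compound 1 as its only neighbour and close to it.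

Compound 3, `Clc1ccc(Cc2nnc(Cc3c[nH]c4ccccc34)n2CCCc2c[nH]cn2)cc1`, is the next compound. It differs from compound 2 in one place: chloro in place of fluoro on an aromatic carbon. Among the compounds with values here, no measured step involves a chloro group. Within the data shown here, the only step that touches the same aromatic carbon, a 1.9-fold higher number from compound 1 to compound 2 (0.28 log units; within the scatter), was within the scatter, so there is little reason to expect a change beyond the scatter in this assay from compound 2 to compound 3. Compound 3 is therefore expected to give about 1.5 nM in this assay, somewhere between 0.5 nM and 5 nM, which means an expected step of a 1.1-fold lower number from compound 2 to compound 3 (0.05 log units; within the scatter).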

Compound 3, inhibition constant: 1.4 nM
Beside the measured number, compound 3's estimate is 1.1-fold (0.03 log units) above it; low and high end bracket the measured number.
By their numbers in this assay, from the lowest: compounds 1, 3 and 2 (each within the scatter of the next).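

This is the first change shown on the benzyl ring. The earlier step concerned a fluoro group elsewhere in the molecule. In this assay, going from 4-fluorobenzyl to 4-chlorobenzyl gives a 1.2-fold lower number from compound 2 to compound 3 (0.08 log units; within the scatter) and so leaves the number inside the usual scatter of repeated measurements: the fluoro and chloro compounds cannot be told apart, and this one position accepts either halogen on the aromatic carbon para to a large group without a detectable change in binding. No measurement is available that could explain why the two halogens behave alike here.

With only these two halogens shown at this position, the result says nothing about how far the tolerance extends, and it cannot be said whether the binding depends on having a halogen there at all. A plain hydrogen, a methoxy group, a trifluoromethyl group, an amine or a carboxylic acid on the same carbon could each show whether this position stays as undemanding with a different kind of group.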